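This account rests on a few compounds, and the source may have more. Where it says the series, first, only, none or still open, it means among the compounds named here.

Measured compounds:
compound 1, `Nc1scc(CN2CCN(c3ccccc3C(F)(F)F)CC2)c1C(=O)c1ccc(Cl)cc1` — -39%
compound 2, `Nc1scc(CN2CCN(c3c(F)cccc3F)CC2)c1C(=O)c1cccc(C(F)(F)F)c1` — 1.3%

Both compounds were tested in a functional assay on CHO cells with adenosine receptor A1 (Homo sapiens) as the target, read by cAMP accumulation and immunoassay, with a stated time of 6 min, tested at 1 uM; a lower number here means a stronger effect, a higher number a weaker effect of the compound at the concentration tested. Compound 1 gives -39% there, the lower of the two numbers, and compound 2 gives 1.3%, a number that lies beyond the usual scatter above it. The two compounds differ from each other in more than one place, so no single change can be tied to that gap.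

Compound 3, `Nc1scc(CN2CCN(c3cc(F)cc(F)c3)CC2)c1C(=O)c1ccc(Cl)cc1`, has not yet been measured. It is derived from compound 1 by one change: 3,5-difluorophenyl in place of 2-(trifluoromethyl)phenyl on an amine nitrogen in a ring. The rest of the molecule, including the ring that carries the chlorine, stays as in compound 1.

Within the data shown here, since no measured pair shows this exact change, the expected step in this assay is uncertain. Among the measured compounds shown here, with only two numbers in hand and compound 1 already at the low end, a modest move toward smaller readings seems more likely than a further fall. Compound 3 is therefore expected to give about -15%, within a range of -45% to 15%, which means an estimated step of a number 24 percentage points higher from compound 1 to compound 3 (beyond the scatter).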

Compound 3, a percentage reported as activity, at one concentration (the size of the read-out at that concentration, not a potency): -66%
Estimate against measurement, compound 3: 51 percentage points above; measured number outside the range, below it.
By their numbers in this assay, from the lowest: compound 3; then compound 1; then compound 2.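

Among these compounds, the swap of 2-(trifluoromethyl)phenyl for 3,5-difluorophenyl on an amine nitrogen in a ring is the first change here that can be read on its own, and in this assay it gives a number 27 percentage points lower from compound 1 to compound 3 (beyond the scatter), so the effect at the tested concentration is stronger. The reading therefore responds to the aromatic ring at this position, and a 2-(trifluoromethyl)phenyl group is not needed there for a low number. No measurement available here explains why the number falls with this swap.

As far as these compounds go, the swap removes the trifluoromethyl group and places two fluorines on the ring in a single step, so the share of each part in the step remains unknown. From the compounds shown here alone, it also remains open what an unsubstituted phenyl, a methoxyphenyl or a pyridine ring would give at this position, and whether 3,5-difluorophenyl would have a similar effect with the 3-(trifluoromethyl)phenyl on the carbonyl of compound 2 in place of the chlorine-bearing ring.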